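This account rests on a few compounds, and the source may have more. Where it says the series, first, only, none or still open, it means among the compounds named here.

Compound 1 `O=C(NS(=O)(=O)c1ccccc1)c1ccc(Nc2nc(NC3(c4ccc(Cl)cc4)CC3)nc(OCC(F)(F)F)n2)cc1` gives 100% in an ADME assay on microsomes from liver (Homo sapiens) for metabolic stability, with a stated time of 10 min; a higher number here means that more of the compound is left, a lower number that less of the compound is left.
Compound 2 `Cc1ccccc1S(=O)(=O)NC(=O)c1ccc(Nc2nc(NC3(c4ccc(Cl)cc4)CC3)nc(OCC(F)(F)F)n2)cc1` gives 100%.
Compound 3 `O=C(NS(=O)(=O)c1ccc(F)cc1)c1ccc(Nc2nc(NC3(c4ccc(Cl)cc4)CC3)nc(OCC(F)(F)F)n2)cc1` gives 100%.

On these numbers compound 3 stands level with the other two: the step of no change at the digits printed from compound 1 to compound 3 (within the scatter) and the step of no change at the digits printed from compound 2 to compound 3 (within the scatter) both lie within the scatter, as does the step of no change at the digits printed from compound 1 to compound 2 (within the scatter). All three measured compounds sit at the top of what this assay can report.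

Compound 4 `O=C(NS(=O)(=O)CCNC(=O)C1CC1)c1ccc(Nc2nc(NC3(c4ccc(Cl)cc4)CC3)nc(OCC(F)(F)F)n2)cc1` differs from compound 3 in one place: 2-((cyclopropylcarbonyl)amino)ethyl in place of 4-fluorophenyl on a sulfonyl sulfur. Going by the values given here, of the measured steps, only the step of no change at the digits printed from compound 2 to compound 3 (within the scatter) touches the same sulfonyl sulfur, and the steps of no change at the digits printed from compound 1 to compound 2 (within the scatter) and no change at the digits printed from compound 1 to compound 3 (within the scatter) alter the same aryl group; none of them swaps the aryl group for a chain, so their bearing on this change is indirect. Since every measured step was flat, compound 4 is expected to stay near the same level, with a small allowance downward. For compound 4 the expected value is 95%, within 80% to 100%. The step of a number 5 percentage points lower from compound 3 to compound 4 (within the scatter) is thus expected to remain within the scatter.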

Compound 4, percent of the compound remaining: 90%
Beside the measured number, compound 4's estimate is 5 percentage points above it, within the range that was stated.
By their numbers in this assay, from the lowest: compounds 4, 1, 2 and 3 (each within the scatter of the next).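

Compound 4 is the first compound shown in which the sulfonyl sulfur, whose other neighbour is an amide-type nitrogen, carries a chain rather than an aryl group: 2-((cyclopropylcarbonyl)amino)ethyl, which has one hydrogen-bond donor and one hydrogen-bond acceptor where the aryl groups have none. In this assay the change reads as a number 10 percentage points lower from compound 3 to compound 4 (within the scatter) and as a number 10 percentage points lower from compound 2 to compound 4 (within the scatter) and as a number 10 percentage points lower from compound 1 to compound 4 (within the scatter) so the aryl group at this position can give way to this chain without a step beyond the scatter. The data shown offer no measurement that would account for this reading.

From the compounds shown here alone, it remains open whether a plain ethyl chain, a longer chain, an amine or a carboxylic acid on the sulfonyl sulfur would stay level with these compounds. Going by these compounds, whether the cyclopropylcarbonyl amide itself contributes to the reading also remains open.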